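Chloro in place of hydroxy on the outer ring

This account rests on a few compounds, and the source may have more. Where it says the series, first, only, none or still open, it means among the compounds named here.

Compound 1 (`COc1ccc(C(=O)/C=C/c2cc3ccccc3[nH]c2=O)cc1`) and compound 2 (`O=C(/C=C/c1cc2ccccc2[nH]c1=O)c1ccc(O)cc1`) share one core and differ only in a methyl on an oxygen on an aromatic ring, which compound 2 lacks. In an ADME assay on MOLT-4 cells (Homo sapiens) for cytotoxicity, read by sulforhodamine B assay, with a stated time of 24 h (a higher number here means that more compound is tolerated, a lower number that less compound is tolerated), compound 1 reaches only the upper limit of the test, > 100000 nM. Compound 2 likewise gives only that limit, > 100000 nM. The step that the two limits leave unreadable from compound 1 to compound 2 therefore cannot be read, and all that is known is the limit of > 100000 nM in this assay, at which 2 of the 2 values shown sit. Compound 3 (`O=C(/C=C/c1cc2ccccc2[nH]c1=O)c1ccc(Cl)cc1`) carries chloro in place of hydroxy on an aromatic carbon. Within the data shown here, the single measured step, a step that the two limits leave unreadable from compound 1 to compound 2, offers no number to build on, so there is no ground for expecting compound 3 to move away from that limit. Compound 3 is accordingly expected to sit at the same limit, estimated at 100000 nM with a range of 30000 nM to 300000 nM, meaning an expected step of a number no higher from compound 2 to compound 3 (the limit leaves the size open).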

Compound 3, concentration lethal to 50% of the cells: > 100000 nM
Compound 3: a limit, no number; the forecaster's own chance of this, stated with the estimate: 80%; the middle value sits exactly at the limit.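

In this assay, among these compounds, compound 3 gives > 100000 nM, a limit and not a number, so no step from compound 1 or compound 2 to compound 3 can be read. The compounds shown leave open how far apart they truly lie, because all share one limit: the limit of > 100000 nM in this assay, at which 3 of the 3 values shown sit.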